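A Nitro for a Fluoro on Two Related Cores

The source may hold more compounds than are shown below. What is called first, only, known or untested is meant among the compounds shown, and "the series" means these compounds.

Two pairs of compounds share one structural change. Compound 2 `COC(=O)c1ccc(CN(CCCc2c(N)nc(N)nc2O)c2cc(F)c(F)cc2[N+](=O)[O-])cc1` and compound 1 `COC(=O)c1ccc(CN(CCCc2c(N)nc(N)nc2O)c2cc(F)c([N+](=O)[O-])cc2[N+](=O)[O-])cc1` differ by nitro in place of fluoro on an aromatic carbon. In a functional assay on CCRF-CEM cells (Homo sapiens) for cytotoxicity, in the absence of a further agent (on this read-out higher numbers stand for weaker inhibition and lower numbers for stronger inhibition), compound 2 gives 59000 nM, and compound 1 gives 2500 nM, which is a 24-fold lower number from compound 2 to compound 1 (1.37 log units; beyond the scatter). Compound 3 `Nc1nc(N)c(CCCN(Cc2ccc(NC(CCC(=O)O)C(=O)O)cc2)c2ccc([N+](=O)[O-])c(F)c2F)c(O)n1` is built on a different core, and the difference between the two cores is not broken down here. In this assay compound 3 reaches only a limit of the assay, > 100000 nM; this value sits at the limit of > 100000 nM in this assay, at which 1 of the 3 values shown sits. Compound 4 `Nc1nc(N)c(CCCN(Cc2ccc(NC(CCC(=O)O)C(=O)O)cc2)c2ccc([N+](=O)[O-])c(F)c2[N+](=O)[O-])c(O)n1` differs from compound 3 by nitro in place of fluoro on an aromatic carbon. This is the same kind of change as before, though here the entering group is ortho to a large group rather than para to it. Compound 4 is expected to move by an at least 3.3-fold lower number from compound 3 to compound 4 (0.52 log units; beyond the scatter), an expectation that rests on a 24-fold lower number from compound 2 to compound 1 (1.37 log units; beyond the scatter). Compound 4 is therefore estimated at 30000 nM, plausibly between 5000 nM and 200000 nM.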

Compound 4, half-maximal inhibitory concentration: 36000 nM
Beside the measured number, compound 4's estimate is 1.2-fold (0.08 log units) below it; measured number inside the range.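

In this assay, nitro in place of fluoro again goes with a lower number on the second core (an at least 2.7-fold lower number from compound 3 to compound 4 (0.44 log units; beyond the scatter)). Compound 3 gives > 100000 nM and that is a limit of the assay, not a number, which makes this step a bound and not a measured size. The direction of the change therefore carries over from one core to the other, but it is not shown whether its size carries over too: the same change on two cores in this assay, a 24-fold lower number (1.37 log units; beyond the scatter) from compound 2 to compound 1 and an at least 2.7-fold lower number (0.44 log units; beyond the scatter) from compound 3 to compound 4; the limit leaves it open whether they differ.

The compounds shown hold only nitro or fluoro at this place, and how an amine or a nitrile there would read stays open. Among the compounds shown here, only two cores appear, and a third core might behave differently.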